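The source may hold more compounds than are shown below. What is called first, only, known or untested is meant among the compounds shown, and "the series" means these compounds.

Compound 1 `CCOc1cc(CCc2nc(C)c(CC)s2)nc(NCc2cc(Cl)cc(NC(=O)OC(C)C)c2)c1`: 33 nM in an assay on cells for binding affinity to Neuropeptide Y receptor type 1 (Homo sapiens); on this read-out higher numbers stand for weaker inhibition and lower numbers for stronger inhibition
Compound 2 `CCCCCOc1cc(CCc2nc(C)c(CC)s2)nc(NCc2cc(Cl)cc(NC(=O)OC(C)C)c2)c1`: 35 nM in this assay

These two compounds share one core and differ only in the length of the chain attached through oxygen to the aromatic ring. In this assay compound 2 sits alongside compound 1, the two numbers lying within the scatter of each other, as the step of a 1.1-fold higher number from compound 1 to compound 2 (0.03 log units; within the scatter) shows. Compound 3 `CCCCCCCOc1cc(CCc2nc(C)c(CC)s2)nc(NCc2cc(Cl)cc(NC(=O)OC(C)C)c2)c1` has not yet been measured in this assay. It differs from compound 2 by ethyl in place of hydrogen on a saturated chain carbon, five bonds along the chain from an oxygen on an aromatic ring. For the measured compounds named here, the only measured step that bears on this change is the one from compound 1 to compound 2, a lengthening of the same chain, and that step stayed within the scatter. Extending the chain once more is therefore expected to give a step of about no change at the digits printed from compound 2 to compound 3 (within the scatter), that is, none beyond the scatter. Compound 3 is estimated to give 35 nM in this assay, with a range from 18 nM to 70 nM.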

Compound 3, half-maximal inhibitory concentration: 72 nM
Compound 3: middle estimate off by 2.1-fold (0.31 log units), on the low side; the whole stated range lies below it.
By their numbers in this assay, from the lowest: compounds 1 and 2 (each within the scatter of the next); then compound 3.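

For the compounds shown here, the chain on the oxygen is not free to grow without limit in this assay as the earlier pair might have suggested: ethyl in place of hydrogen, five bonds along the chain from an oxygen on an aromatic ring, gives a 2.1-fold higher number from compound 2 to compound 3 (0.31 log units; beyond the scatter) and is the first step here beyond the scatter. Set against the shortest chain shown, pentyl in place of hydrogen gives a 2.2-fold higher number from compound 1 to compound 3 (0.34 log units; beyond the scatter) and so the loss is modest, yet it appears only with the last extension and not with the first. Nothing available here explains why the number rises at this chain length.

The compounds shown leave open whether a still longer chain such as nonyl would push the number further up, and whether a hexyl chain would already do so. A chain of similar length ending in an amine or a carboxylic acid also remains an open case.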